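The compounds below may be only part of what the source reports. "The series", "measured", "known", "first", "only" and "open" are said of these compounds alone.

In a functional assay on SMMC-7721 cells (Homo sapiens) for cytotoxicity, read by MTT assay, with a stated time of 72 h (on this read-out higher numbers stand for weaker inhibition and lower numbers for stronger inhibition), two compounds have been read so far. Compound 1 `CC(=O)c1ccc(NC(=O)CSC(=S)N[C@H]2CCOC2=O)cc1` returned only a limit, > 128000 nM, and not a number. For the measured compounds named here, compound 2 `O=C(CCl)Nc1ccc(C(=O)/C=C/c2ccc(Cl)cc2)cc1` gave 8160 nM, which makes it the only compound with an actual number on this read-out. Compound 3 `O=C(CCl)Nc1ccc(C(=O)/C=C/c2cccc(Cl)c2)cc1` is still to be measured. It has the same atoms as compound 2, joined differently, with 3-chlorophenyl in place of 4-chlorophenyl on a double-bonded chain carbon bound to a double-bonded chain carbon. Going by the values given here, no step between measured compounds is available to guide the comparison. Starting from compound 2 at 8160 nM, the expected step in this assay, a 1.0-fold lower number from compound 2 to compound 3 (0.01 log units; within the scatter), stays within the usual scatter and has no expected direction. For compound 3 the estimated value is 8000 nM, with an expected range of 3000 nM to 22000 nM.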

Compound 3, half-maximal inhibitory concentration: 7760 nM
Beside the measured number, compound 3's estimate is 1.0-fold (0.01 log units) above it; low and high end bracket the measured number.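

In this assay, 3-chlorophenyl in place of 4-chlorophenyl on a double-bonded chain carbon bound to a double-bonded chain carbon gives the first step read at this position, and that step is small: a 1.1-fold lower number from compound 2 to compound 3 (0.02 log units; within the scatter). Until now a single number stood at this position, so it could not be said whether the place of the chlorine on the phenyl ring mattered; here the two placements read alike in this cell assay. Nothing measured here gives a reason for this result.

The compounds shown leave open whether a methoxy group or a nitrile in place of the ring chlorine would read differently from these two chlorophenyl compounds. They also leave open what an amine would do in place of the chlorine on the chloroacetamide chain.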